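The compounds below may be only part of what the source reports. "The series", "measured", "known", "first", "only" and "open" are said of these compounds alone.

Compound 2 `Cc1ccc(-c2cs/c(=N/NC(=O)CSc3nncn3C)n2-c2ccccc2)cc1` gives the lower of the two numbers recorded in a functional assay on C6 cells (Rattus norvegicus) for cytotoxicity, read by MTT assay, with a stated time of 24 h, tested at 6 ug/mL; a higher number here means a weaker effect of the compound at the concentration tested, a lower number a stronger effect: compound 2 shows 74.6%, while compound 1 `Cc1ccc(-c2cs/c(=N/NC(=O)CSc3ncccn3)n2-c2ccccc2)cc1` shows 93.2%. Among the measured compounds shown here, the one measured step, a number 18.6 percentage points lower from compound 1 to compound 2 (beyond the scatter), exchanges a different ring on the same sulfur, so it bears only loosely on the step to compound 3 `Cc1ccc(-c2cs/c(=N/NC(=O)CSc3nnc(C)s3)n2-c2ccccc2)cc1`, in which (5-methyl-1,3,4-thiadiazol-2-yl in place of 4-methyl-4H-1,2,4-triazol-3-yl on a sulfur). For the measured compounds named here, no measured step covers this exchange, so no shift beyond the scatter is expected in this assay , and for compound 3 a value of 76% is estimated, within 60% to 92%, which would mean an expected step of a number 1.4 percentage points higher from compound 2 to compound 3 (within the scatter).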

Compound 3, a percentage reported as activity, at one concentration (the size of the read-out at that concentration, not a potency): 65.9%
Compound 3: the middle estimate sits 10.1 percentage points above what was measured; the range from low to high includes it.
By their numbers in this assay, from the lowest: compounds 3 and 2 (each within the scatter of the next); then compound 1.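

In this assay, 5-methyl-1,3,4-thiadiazol-2-yl in place of 4-methyl-4H-1,2,4-triazol-3-yl on the sulfur gives a number 8.7 percentage points lower from compound 2 to compound 3 (within the scatter), so exchanging a ring nitrogen for sulfur does not separate these two groups here. Measured against pyrimidin-2-yl, the same group gives a number 27.3 percentage points lower from compound 1 to compound 3 (beyond the scatter), so a second five-membered aromatic ring now stands apart from pyrimidin-2-yl. No measurement shown explains either result.

As far as these compounds go, it remains open whether an amine in place of the methyl on the thiadiazole ring would keep this effect. A plain phenyl on the sulfur is also an open case.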